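The source may report more compounds than this note shows. Statements on the series, on what has been measured and on what is new or still open speak of the compounds shown alone.

Compound 1 `Cc1ccc(S(=O)(=O)NC(C)C)cc1C#Cc1cc(Cl)ccc1OCC(=O)O` is the reference point of this account. In an assay on CHO cells for displacement of a labelled ligand from prostaglandin D2 receptor 2 (Homo sapiens), read by scintillation counting (on this read-out higher numbers stand for weaker inhibition and lower numbers for stronger inhibition), compound 1 gives 3.4 nM, the lowest number among the three measured compounds. Compound 2 `CC(C)c1ccc(S(C)(=O)=O)cc1C#Cc1cc(Cl)ccc1OCC(=O)O` gives 4.6 nM in this assay, a value within the scatter of compound 1, so no order between the two can be read. Compound 3 `O=C(O)COc1ccc(Cl)cc1C#Cc1cncc(S(=O)(=O)N2CCOCC2)c1` gives 41 nM in this assay, which lies beyond the scatter above compound 1; compound 3 differs from compound 1 in more than one place, so this gap is not tied to a single change.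

The step under consideration leads from compound 1 to compound 4 `Cc1ccc(S(=O)(=O)N(C)CCN(C)C)cc1C#Cc1cc(Cl)ccc1OCC(=O)O`. The change is (2-(dimethylamino)ethyl)(methyl)amino in place of isopropylamino on a sulfonyl sulfur. Compounds 1 and 2, which carry different groups on the sulfonyl sulfur, sit within the scatter of each other, which suggests that this position tolerates variation, while compound 3, with a third group there and other changes besides, is weaker. For the measured compounds named here, no measured pair isolates this exact change. Compound 4 is expected to give 8 nM in this assay, with a range from 2.5 nM to 30 nM. The step expected here is a 2.4-fold higher number from compound 1 to compound 4 (0.37 log units; beyond the scatter), a modest shift toward higher numbers that may well fall within the scatter.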

Compound 4, inhibition constant: 369 nM
Estimate against measurement, compound 4: 46-fold (1.66 log units) below, outside the stated range (above it).
By their numbers in this assay, from the lowest: compounds 1 and 2 (each within the scatter of the next); then compound 3; then compound 4.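

In this assay, (2-(dimethylamino)ethyl)(methyl)amino in place of isopropylamino on a sulfonyl sulfur gives a 110-fold higher number from compound 1 to compound 4 (2.04 log units; beyond the scatter), a large step and the only one here that isolates a change at this place. For the compounds shown here, it shows that this position is not indifferent to the group it carries, which the earlier compounds, differing from one another in more than one place, could not show. The change is also a composite one, with 7 heavy atoms entering for 4 and the hydrogen-bond donor of isopropylamino absent from the entering group, and nothing measured here explains the step or assigns it to any of these differences.

The compounds shown leave open whether the step follows the loss of the sulfonamide hydrogen, the added methyl on that nitrogen, or the dimethylamino end of the chain. A 2-(dimethylamino)ethylamino group, which keeps that hydrogen, and a 2-methoxyethylamino group, which ends in an ether oxygen instead of an amine, would separate these possibilities.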